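The compounds below may be only part of what the source reports. "The series", "measured", "known", "first", "only" and "open" are said of these compounds alone.

Compound 1 `CC(C)=CCC1Cc2c(O)cc(=O)n(CCCO)c2CC1(C)C` is the starting point of this comparison. Among the compounds with values here, in a functional assay on PANC-1 cells (Homo sapiens) for inhibition, read by MTT assay, with a stated time of 24 h, tested at 10 uM (a higher number here means more inhibition at the concentration tested (going by the name of the read-out), a lower number less inhibition), compound 1 gives 25.6%, which places it second highest among the three numbers measured so far. Compound 2 `CC(C)=CCC1Cc2c(OCCCOc3ccc(Cl)cc3)cc(=O)n(CCCO)c2CC1(C)C` carries a 3-(4-chlorophenoxy)propyl group where compound 1 has a hydrogen; in this assay compound 2 gives 22.7%, and the step of a number 2.9 percentage points lower from compound 1 to compound 2 (within the scatter) stays within the scatter of the method. Compound 3 `CC(C)=CCC1Cc2c(OC(=O)Nc3cccc(F)c3)cc(=O)n(CCCO)c2CC1(C)C` carries a (3-fluorophenyl)carbamoyl group on the same oxygen; in this assay compound 3 gives 66.1%, and the step of a number 40.5 percentage points higher from compound 1 to compound 3 (beyond the scatter) is large, as is the step of a number 43.4 percentage points higher from compound 2 to compound 3 (beyond the scatter).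

Compound 4 `CC(C)=CCC1Cc2c(OC(=O)Nc3ccc(F)cc3F)cc(=O)n(CCCO)c2CC1(C)C` has not yet been measured. It differs from compound 1 by (2,4-difluorophenyl)carbamoyl in place of hydrogen on an oxygen on an aromatic ring. The step from compound 1 to compound 3 bears most directly on this change, since both carbamoyl groups sit on the same oxygen and differ only in the fluorine substitution of the phenyl ring. That step was large and upward, whereas the step to compound 2 showed that not every group on this oxygen shifts the reading. An upward step of similar size is therefore expected, as a number 34.4 percentage points higher from compound 1 to compound 4 (beyond the scatter). Compound 4 is estimated to give 60%, with a range from 40% to 78%.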

Compound 4, a percentage reported as inhibition, at one concentration (the size of the read-out at that concentration, not a potency): 69.7%
Compound 4: the middle estimate sits 9.7 percentage points below what was measured; the measured number falls inside the stated range.
By their numbers in this assay, from the lowest: compounds 2 and 1 (each within the scatter of the next); then compounds 3 and 4 (each within the scatter of the next).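

Placing (2,4-difluorophenyl)carbamoyl on this oxygen gives a number 44.1 percentage points higher from compound 1 to compound 4 (beyond the scatter) in this assay, so the large rise seen earlier is now shared by two different fluorophenyl carbamoyl groups rather than resting on a single compound. Changing 3-fluorophenyl to 2,4-difluorophenyl on the amide-type nitrogen gives a number 3.6 percentage points higher from compound 3 to compound 4 (within the scatter) and so makes no readable difference, which means these two fluorine patterns cannot be told apart at this single test concentration. The comparison with the ether chain gives a number 47 percentage points higher from compound 2 to compound 4 (beyond the scatter), so among these four compounds the two carbamoyl compounds form a high pair, while compound 2, despite its large group on the same oxygen, stays level with compound 1, which has only hydrogen there.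

From the compounds shown here alone, what remains open is whether the high readings need the fluorine atoms, the phenyl ring or only the carbamoyl part, a question that a plain phenylcarbamoyl, a methylcarbamoyl or an acetyl group on this oxygen could help to settle. No measurement at hand explains why the carbamoyl groups and the ether chain part ways.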